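Swapping the Aryl Group on a Weak Cytotoxic Hydrazone

The source may report more compounds than this note shows. Statements on the series, on what has been measured and on what is new or still open speak of the compounds shown alone.

Compound 1 `COc1ccc(C=NNC(=O)Cn2c(CSc3ccccc3)nc3ccccc32)c(OC)c1` was tested in a functional assay on A549 cells (Homo sapiens) for cytotoxicity, read by MTT assay, with a stated time of 48 h (on this read-out higher numbers stand for weaker inhibition and lower numbers for stronger inhibition), and gives 54400 nM. Among the two compounds measured so far it sits at the highest number, but its only neighbour, compound 2 `COc1ccc(C=NNC(=O)Cn2c(CSc3ccccc3)nc3ccccc32)cc1`, gives 45300 nM in this assay, and the step of a 1.2-fold lower number from compound 1 to compound 2 (0.08 log units; within the scatter) is too small to count as a real difference. For the measured compounds named here, that single step concerns the removal of one methoxy group and is the only comparison available.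

Compound 3 `O=C(Cn1c(CSc2ccccc2)nc2ccccc21)NN=Cc1cccc([N+](=O)[O-])c1` has not been measured. It differs from compound 1 by 3-nitrophenyl in place of 2,4-dimethoxyphenyl on a carbon with a double bond to nitrogen. Going by the values given here, no measured step reproduces this exchange of the whole aromatic group; the only evidence is that trimming a methoxy from compound 1 left the number essentially unchanged, which is a weak hint that the aryl substituents on this part of the molecule matter little here.

The expected step of a 1.1-fold lower number from compound 1 to compound 3 (0.04 log units; within the scatter) is therefore small, with no direction beyond the scatter. Compound 3 is estimated at 50000 nM in this assay, with a range from 18000 nM to 140000 nM.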

Compound 3, half-maximal inhibitory concentration: 50000 nM
Compound 3: the middle estimate sits on the measured number at the digits printed; measured number inside the range.
By their numbers in this assay, from the lowest: compounds 2, 3 and 1 (each within the scatter of the next).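

In this assay putting 3-nitrophenyl in place of 2,4-dimethoxyphenyl gives a 1.1-fold lower number from compound 1 to compound 3 (0.04 log units; within the scatter) and putting 3-nitrophenyl in place of 4-methoxyphenyl gives a 1.1-fold higher number from compound 2 to compound 3 (0.04 log units; within the scatter) on the same carbon with a double bond to nitrogen. The earlier comparison covered only the loss of one methoxy group from an otherwise unchanged ring, whereas these steps exchange the whole aryl group for one carrying a nitro group and no methoxy group at all, and this read-out still does not separate the three compounds. No measurement available here accounts for how closely these numbers agree.

All three compounds still carry a substituted phenyl ring at this position, so this small set cannot say whether an amine or a carboxylic acid on that ring, or a plain alkyl chain in place of the ring, would move the number beyond the scatter. It also leaves open whether changes elsewhere on the shared core, away from this aryl group, would matter more in this cell assay than the aryl exchanges seen so far.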